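Amide to urea on the anilide arm of compound 1

This account rests on a few compounds, and the source may have more. Where it says the series, first, only, none or still open, it means among the compounds named here.

Measured compounds:
compound 1, `COc1cc(-c2nn(-c3cccc(NC(=O)c4cccc(C(F)(F)F)c4)c3)cc2-c2ccncc2)ccc1Cl` — in a functional assay on NCI-H460 cells (Homo sapiens) for inhibition, read by sulforhodamine B assay, with a stated time of 48 h (on this read-out lower numbers stand for stronger inhibition of growth and higher numbers for weaker inhibition of growth), compound 1 gives 1450 nM
compound 2, `O=C(Nc1cccc(-n2cc(-c3ccncc3)c(-c3ccc(Cl)c(O)c3)n2)c1)Nc1cc(C(F)(F)F)cc(C(F)(F)F)c1` — in this assay compound 2 gives 413 nM

Compound 1 stands at the highest of the two numbers, the weaker of the two growth inhibitors; compound 2 sits clearly lower, beyond the scatter. Among the compounds with values here, no pair differing in a single place has been measured, so no step between measured compounds can be read off, and the gap between compound 1 and compound 2 spans more than one change.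

Compound 3, `COc1cc(-c2nn(-c3cccc(NC(=O)Nc4ccc(Cl)c(Cl)c4)c3)cc2-c2ccncc2)ccc1Cl`, is compound 1 with a single change: (3,4-dichlorophenyl)amino in place of 3-(trifluoromethyl)phenyl on a carbonyl carbon. The amide of compound 1 becomes a urea in compound 3, with the trifluoromethyl ring replaced by a dichlorinated ring; the rest of the shared core, including the methoxy and chloro substitution on the third aryl ring, is unchanged.

The only urea among the measured compounds, compound 2, gives the lower number in this assay, though it also differs from compound 1 elsewhere, so this is a weak hint rather than a step. A move to a lower number, of modest size, is expected for compound 3, a 2.2-fold lower number from compound 1 to compound 3 (0.35 log units; beyond the scatter). Compound 3 is estimated at 650 nM, with a range from 250 nM to 1700 nM.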

Compound 3, concentration for 50% growth inhibition: 1110 nM
Compound 3: the middle estimate sits 1.7-fold (0.23 log units) below what was measured; the range from low to high includes it.
By their numbers in this assay, from the lowest: compound 2; then compounds 3 and 1 (each within the scatter of the next).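

Within the data shown here, at this position, on a carbonyl carbon whose other neighbour is an amide-type nitrogen, (3,4-dichlorophenyl)amino in place of 3-(trifluoromethyl)phenyl gives a 1.3-fold lower number from compound 1 to compound 3 (0.12 log units; within the scatter) in this assay, and this is the only single-place step available. The amide-to-urea change, with its one added hydrogen-bond donor and the exchange of the trifluoromethyl ring for the dichlorinated ring, therefore comes with no difference in growth inhibition that can be told from the scatter, so in this pair the urea by itself gives no gain. No independent measurement bears on why the two compounds read alike.

The step changes the linker and the ring substituents together, so their separate contributions cannot be read, and effects that offset each other cannot be distinguished from two changes that each do nothing. From the compounds shown here alone, a urea carrying (3-(trifluoromethyl)phenyl)amino on the same carbonyl carbon would separate the two, and whether other groups here, such as a sulfonamide linker or a pyridyl ring, would move the number also remains open.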